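Piperazine amides on a shared core: outlook for compound 3

This account rests on a few compounds, and the source may have more. Where it says the series, first, only, none or still open, it means among the compounds named here.

Measured so far:
compound 1, `Cn1nnnc1SCC(=O)Nc1ccc(-c2nc(-c3ccccc3)c(-c3ccccc3)n2C)cc1`, 21.9%
compound 2, `CN1CCN(CC(=O)Nc2ccc(-c3nc(-c4ccccc4)c(-c4ccccc4)n3C)cc2)CC1`, 1.1%

In a functional assay on MCF7 cells (Homo sapiens) for cytotoxicity, read by MTT assay, with a stated time of 24 h, tested at 0.64 ug/mL (a lower number here means a weaker effect, a higher number a stronger effect of the compound at the concentration tested), compound 2 gives 1.1%, the lowest of the two numbers. Compound 1 gives 21.9%. Within the data shown here, the only measured step is a number 20.8 percentage points lower from compound 1 to compound 2 (beyond the scatter), which exchanges the whole group on the chain carbon and does not touch the ring nitrogen. Compound 3, `Cn1c(-c2ccc(NC(=O)CN3CCN(c4ccccc4)CC3)cc2)nc(-c2ccccc2)c1-c1ccccc1`, differs from compound 2 by phenyl in place of methyl on an amine nitrogen in a ring. Among the measured compounds shown here, no measured step bears on this change, so no step beyond the scatter is expected: the estimated step is a number 6.9 percentage points higher from compound 2 to compound 3 (within the scatter). Compound 3 is expected to give 8% in this assay, within 0% to 30%.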

Compound 3, a percentage reported as activity, at one concentration (the size of the read-out at that concentration, not a potency): 12.1%
Beside the measured number, compound 3's estimate is 4.1 percentage points below it; the measured number falls inside the stated range.
By their numbers in this assay, from the lowest: compound 2; then compounds 3 and 1 (each within the scatter of the next).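

The amine nitrogen in the ring is a position that responds in this assay: with phenyl in place of methyl, the read-out shows a number 11 percentage points higher from compound 2 to compound 3 (beyond the scatter) and so is not fixed by the ring alone. The loss seen with 4-methylpiperazin-1-yl does not hold for every ring amine on the chain carbon, as 4-phenylpiperazin-1-yl gives a number 9.8 percentage points lower from compound 1 to compound 3 (within the scatter) against the (1-methyl-1H-tetrazol-5-yl)sulfanyl group. Nothing available accounts for either step.

Open, going by these compounds, is whether a benzyl group or a pyridyl ring on that nitrogen would raise the number further. Also open, on these data alone, is what a longer chain would do in place of the single chain carbon.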